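From Ethyl to Isopropyl on the Shared Core

The source may report more compounds than this note shows. Statements on the series, on what has been measured and on what is new or still open speak of the compounds shown alone.

Compound 3 `CCc1nc(C(=O)OC)nn1-c1ccc(F)cc1` was measured in a functional assay on Jurkat cells (Homo sapiens) for inhibition, read by MTT assay, with a stated time of 72 h (a higher number here means a weaker inhibitor of growth, a lower number a stronger inhibitor of growth), where compound 3 gives 11000 nM. Among the three measured compounds its number stands second highest; the nearest is compound 2 `COC(=O)c1nc(C)n(-c2ccc(F)cc2)n1`, which gives 8700 nM, and the furthest is compound 1 `COC(=O)c1nc(C)n(-c2ccc(Cl)cc2)n1`, which gives 65900 nM. The step of a 1.3-fold higher number from compound 2 to compound 3 (0.10 log units; within the scatter) lies within the scatter, whereas the step of a 7.6-fold lower number from compound 1 to compound 2 (0.88 log units; beyond the scatter) is beyond it.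

Compound 4 `COC(=O)c1nc(C(C)C)n(-c2ccc(F)cc2)n1` has not yet been measured. It differs from compound 3 by methyl in place of hydrogen on a saturated chain carbon bound to an aromatic carbon and a saturated chain carbon; seen one bond further out, this reads as ethyl to isopropyl. The step of a 1.3-fold higher number from compound 2 to compound 3 (0.10 log units; within the scatter), in which a methyl entered at the same kind of position, bears on this change and stayed within the scatter. The step of a 7.6-fold lower number from compound 1 to compound 2 (0.88 log units; beyond the scatter) concerns the halogen on the aromatic ring and does not bear on it. One more methyl on the same chain is therefore expected to move the number in this assay little, if at all, with no step beyond the scatter. Compound 4 is estimated at 13000 nM in this assay, between 5000 nM and 35000 nM. This estimate means an expected step of a 1.2-fold higher number from compound 3 to compound 4 (0.07 log units; within the scatter).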

Compound 4, concentration for 50% growth inhibition: > 100000 nM
Compound 4: only a limit was reported; the forecaster's own chance of this, stated with the estimate: 5%; middle value at least 7.6-fold (0.88 log units) from the limit.
By their numbers in this assay, from the lowest: compounds 2 and 3 (each within the scatter of the next); then compound 1. At a limit, above all of these: compound 4.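

In this assay, for the compounds shown here, compound 4 gives > 100000 nM, which is a limit of the assay and not a number, and the only such reading among the values shown: the limit of > 100000 nM in this assay, at which 1 of the 4 values shown sits. The same kind of change, a methyl in place of a hydrogen on the chain, gave a 1.3-fold higher number from compound 2 to compound 3 (0.10 log units; within the scatter) at the first extension, but ethyl to isopropyl gives an at least 9.0-fold higher number from compound 3 to compound 4 (0.95 log units; beyond the scatter). Read as a single replacement, isopropyl in place of methyl on an aromatic carbon gives an at least 11-fold higher number from compound 2 to compound 4 (1.06 log units; beyond the scatter), so this position tolerates ethyl in this assay while the number climbs out of range with isopropyl.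

On these data alone, whether a straight propyl chain or a cyclopropyl ring here would read like ethyl or like isopropyl stays open. Also open, as far as these compounds go, is whether chloro in place of fluoro on the aromatic ring would shift the picture for these larger groups.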